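A few compounds are considered here, and "the series" means these few. Any claim that something is new, unique, unknown or untested is made for them only; others in the source may bear on it.

Compound 1, whose structure is `Oc1ccc(-c2cc(-c3ccc(Cl)cc3)nc(-c3cccnc3)c2)cc1`, serves as the starting point. In an ADME assay on HEK293 cells (Homo sapiens) for cytotoxicity, read by CCK-8 assay and cell counting, with a stated time of 2 days (a lower number here means a stronger inhibitor, a higher number a weaker inhibitor), compound 1 gives 27500 nM. Compound 2, with structure `Oc1ccc(-c2cc(-c3ccc(Cl)cc3)nc(-c3cccs3)c2)cc1`, differs from compound 1 by a single change, (thiophen-2-yl in place of pyridin-3-yl on an aromatic carbon), and in this assay compound 2 gives 4520 nM. That change produced a 6.1-fold lower number from compound 1 to compound 2 (0.78 log units; beyond the scatter), a step that lies beyond the usual scatter of such measurements.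

Compound 3, with structure `Oc1cccc(-c2cc(-c3cccnc3)nc(-c3ccccc3Cl)c2)c1`, carries the same atoms as compound 1 joined differently; the difference between the two cores is not broken down here, and in this assay compound 3 gives "not determined" (no result reported), so no single number for it is available.

Compound 4, with structure `Oc1cccc(-c2cc(-c3cccs3)nc(-c3ccccc3Cl)c2)c1`, arises from compound 3 by thiophen-2-yl in place of pyridin-3-yl on an aromatic carbon. This is the same kind of change as that from compound 1 to compound 2, but not the same, since the place now lies meta to a 2-chlorophenyl group and meta to a 3-hydroxyphenyl group rather than meta to a 4-chlorophenyl group and a 4-hydroxyphenyl group. Without a value for compound 3, the expectation for compound 4 rests only on compound 2, which gave 4520 nM, so for compound 4 a value of about 6000 nM is estimated, within a range from 1500 nM to 30000 nM.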

Compound 4, half-maximal inhibitory concentration: 2600 nM
Compound 4: the middle estimate sits 2.3-fold (0.36 log units) above what was measured; measured number inside the range.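

No new step can be read from compound 3 to compound 4, since compound 3 has no number in this assay to set against compound 4. Nothing shown offers an explanation for the result for compound 4. Still open, going by these compounds, is whether thiophen-2-yl in place of pyridin-3-yl changes the number as much here as it does between compound 1 and compound 2.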